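This account rests on a few compounds, and the source may have more. Where it says the series, first, only, none or still open, it means among the compounds named here.

Compound 2 `CC(C)(C)c1cc(N)c2cc(NC(=O)/C=C/c3ccc(C(F)(F)F)cc3)ccc2n1` is the stronger of the two measured compounds in an assay on isolated protein for displacement of a labelled ligand from melanin-concentrating hormone receptor 1 (Homo sapiens); a lower number here means a stronger inhibitor, a higher number a weaker inhibitor. Compound 2 gives 0.3 nM. Among the measured compounds shown here, the only other measured compound is compound 1 `CCCc1cc(N)c2cc(NC(=O)CCc3ccccc3)ccc2n1`, which differs from compound 2 in more than one place, and compound 1 gives 8300 nM; the two numbers lie far apart, well beyond the scatter, so compound 2 stands clearly at the low end of what has been measured.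

Compound 3 `Nc1cc(C2CCCC2)nc2ccc(NC(=O)/C=C/c3ccc(C(F)(F)F)cc3)cc12` has not yet been measured. It differs from compound 2 in one place only: cyclopentyl in place of tert-butyl on an aromatic carbon. For the measured compounds named here, nothing among the measured compounds shows what such an exchange does here, since compound 1 and compound 2 differ in several places at once and no single step has been isolated. Going by the values given here, the exchange is a small one by count, one group of four carbon atoms giving way to one of five carbon atoms that form a ring, so no large step in this assay is expected from it.

On that basis compound 3 is expected to give about 0.6 nM, within a range from 0.15 nM to 3 nM, which would mean an estimated step of a 2.0-fold higher number from compound 2 to compound 3 (0.30 log units; within the scatter), a modest drift toward a weaker value if any.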

Compound 3, half-maximal inhibitory concentration: 0.8 nM
Beside the measured number, compound 3's estimate is 1.3-fold (0.12 log units) below it; low and high end bracket the measured number.
By their numbers in this assay, from the lowest: compound 2; then compound 3; then compound 1.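

Among the compounds shown here, the exchange of tert-butyl for cyclopentyl is the first single change that can be read in this assay, and it gives a 2.7-fold higher number from compound 2 to compound 3 (0.43 log units; beyond the scatter), a modest step that lies beyond the scatter. It shows that this position, on an aromatic carbon next to the ring nitrogen, can carry a five-membered non-aromatic ring of carbon only in place of tert-butyl at a small cost, with compound 3 still at 0.8 nM. The data offer no measurement that accounts for the direction or size of this step.

The compounds shown leave open how the number would respond to other groups at this position, such as a cyclohexyl ring, a phenyl ring, a longer alkyl chain or an amine, since tert-butyl and cyclopentyl are the only two groups that can be set side by side here. Compound 2 and compound 3 each differ in more than one place from compound 1, so steps to it cannot be read, and its 8300 nM cannot be divided among those places.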